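Chloro for Fluoro on a Bromoacrylamide Series

The compounds below may be only part of what the source reports. "The series", "measured", "known", "first", "only" and "open" are said of these compounds alone.

Compound 1: `Nc1cccc(-c2cn3nc(-c4cccs4)sc3n2)c1`, > 250000 nM
Compound 2: `C=C(Br)C(=O)Nc1cccc(-c2cn3nc(-c4ccc(F)cc4)sc3n2)c1`, 870 nM
Compound 3: `Nc1cccc(-c2cn3c(-c4ccc(Cl)cc4)csc3n2)c1`, 17000 nM

In a functional assay on HeLa cells (Homo sapiens) for inhibition, read by cell counting, with a stated time of 4 days (a lower number here means a stronger inhibitor, a higher number a weaker inhibitor), compound 2, with the structure `C=C(Br)C(=O)Nc1cccc(-c2cn3nc(-c4ccc(F)cc4)sc3n2)c1`, gives 870 nM. This is the lowest of the two actual numbers in the set. Compound 3, with the structure `Nc1cccc(-c2cn3c(-c4ccc(Cl)cc4)csc3n2)c1`, gives 17000 nM in this assay, a higher number than compound 2, and the gap between them is beyond the scatter of repeated measurements. Compound 1, with the structure `Nc1cccc(-c2cn3nc(-c4cccs4)sc3n2)c1`, is reported only as a limit of this assay, > 250000 nM, and not as a number; (the limit of > 250000 nM in this assay, at which 1 of the 3 values shown sits).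

The next compound, compound 4, has the structure `C=C(Br)C(=O)Nc1cccc(-c2cn3nc(-c4ccc(Cl)cc4)sc3n2)c1` and is yet to be measured in this assay. It differs from compound 2 in one place: chloro in place of fluoro on an aromatic carbon. Among the compounds with values here, the change sits on the six-membered aromatic ring, away from the bromoacrylamide that compound 2 and compound 4 share, and no measured pair in this set shows what such a swap does on its own.

The expectation is therefore a step of a 1.2-fold lower number from compound 2 to compound 4 (0.09 log units; within the scatter), that is, no change beyond the scatter in either direction. Compound 4 is estimated at 700 nM in this assay, within a range from 250 nM to 2000 nM.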

Compound 4, half-maximal inhibitory concentration: 3000 nM
The estimate for compound 4 lay 4.3-fold (0.63 log units) below the measured number; the measured number lies above the stated range.
By their numbers in this assay, from the lowest: compound 2; then compound 4; then compound 3. At a limit, above all of these: compound 1.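

In this assay, within the data shown here, exchanging 4-fluorophenyl for 4-chlorophenyl gives a 3.4-fold higher number from compound 2 to compound 4 (0.54 log units; beyond the scatter), and this is the first pair in the set that differs in only one place. It shows that this position, para to a large group, is not indifferent to the choice of halogen: with the bromoacrylamide and the shared core held constant, a single atom moves the number beyond the scatter, although the step is only modest, and here the fluoro compound has the lower number. The numbers show the size and direction of this step but not its cause, and nothing measured here bears on why chloro and fluoro differ in this way.

One swap cannot show whether the trend continues through other groups at this position, such as methoxy, methyl or trifluoromethyl, or whether a plain hydrogen there would give a lower or a higher number than fluoro. It also leaves open whether the same exchange would have a similar effect in a compound carrying a free amine in place of the bromoacrylamide.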